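The source may hold more compounds than are shown below. What is called first, only, known or untested is meant among the compounds shown, and "the series" means these compounds.

Measured so far in a functional assay on HEK293 cells for negative allosteric modulation of metabotropic glutamate receptor 5 (Homo sapiens), read by HTRF and inositol phosphate accumulation; on this read-out lower numbers stand for stronger inhibition and higher numbers for weaker inhibition:
compound 1 `CCC[C@H](NC(=O)c1nccs1)c1cnc(Nc2ccc(C)nc2)c(Cl)c1` — 978 nM
compound 2 `Cc1ccc(Nc2ncc([C@@H](NC(=O)c3nccs3)C(C)C)cc2Cl)cn1` — 1060 nM
compound 3 `Cc1ccc(Nc2ncc([C@H](NC(=O)c3nccs3)C(C)(C)C)cc2Cl)cn1` — 30.9 nM

Compound 3 gives the lowest number of the three, and its gap to compound 1 and to compound 2 is beyond the scatter in both cases. Compound 4 `C=CC[C@@H](NC(=O)c1nccs1)c1cnc(Nc2ccc(C)nc2)c(Cl)c1` keeps the shared core and differs from compound 3 in one place only: allyl in place of tert-butyl on a saturated chain carbon bound to an amide-type nitrogen and an aromatic carbon.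

Among the measured compounds shown here, only one measured step touches this position, a 1.1-fold higher number from compound 1 to compound 2 (0.03 log units; within the scatter). It exchanged one chain of three carbons for another and left the number essentially unchanged. Neither propyl nor isopropyl is tert-butyl or allyl, so the exact exchange in hand has not been measured. What the numbers do show is that both three-carbon chains, in compound 1 and compound 2, sit far above the tert-butyl of compound 3. Allyl is again a chain of three carbons, so compound 4 is expected to move back toward the region of those two compounds. The expected step is a 26-fold higher number from compound 3 to compound 4 (1.41 log units; beyond the scatter), a large rise in this assay. Compound 4 is therefore estimated at 800 nM. As far as these compounds go, the double bond of allyl is untested here, so the expected range for compound 4 is wide, from 250 nM to 2500 nM.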

Compound 4, half-maximal inhibitory concentration: 2.4 nM
Beside the measured number, compound 4's estimate is 330-fold (2.52 log units) above it, outside the stated range (below it).
By their numbers in this assay, from the lowest: compound 4; then compound 3; then compounds 1 and 2 (each within the scatter of the next).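

Exchanging tert-butyl for allyl on the saturated chain carbon bound to an amide-type nitrogen and an aromatic carbon gives a 13-fold lower number from compound 3 to compound 4 (1.11 log units; beyond the scatter) in this assay. Among the compounds shown here, this is the first measured change at this position that is clearly beyond the scatter in a single step, and it shows that the group placed here can shift the number strongly, with the smaller allyl giving the lower value of this pair. Compound 4 also shows that having a chain of three carbons here does not by itself bring a high number, as compound 4 carries one and still gives 2.4 nM, while no measurement available accounts for this gain.

Compounds 1 and 2 are drawn with the opposite spatial arrangement at this carbon from compounds 3 and 4, so these compounds do not separate the effect of that arrangement from the effect of the chain itself. As far as these compounds go, it also remains open whether the double bond matters, which a propyl group drawn with the arrangement of compound 4 would test, and how a cyclopropyl ring or a longer chain such as butyl would behave here.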